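The source may hold more compounds than are shown below. What is called first, only, known or untested is meant among the compounds shown, and "the series" means these compounds.

Compound 1 `O=C(O)CC/C=C\CO[C@H]1C(OCc2ccc(-c3ccccc3)cc2)CC[C@@H]1N1CCCCCC1` and compound 2 `O=C(O)CC/C=C\CO[C@H]1C(OCc2ccc(-c3ccccc3CCO)cc2)CC[C@@H]1N1CCCCCC1` share one core and differ in a single place, where compound 2 carries a 2-hydroxyethyl group on an aromatic carbon. In a functional assay for antagonist activity at thromboxane A2 receptor (Rattus norvegicus) (on this read-out lower numbers stand for tighter binding and higher numbers for weaker binding), compound 1 gives 25.1 nM, and compound 2 gives 31.6 nM. Among the measured compounds shown here, compound 2 thus stands at the higher of the two numbers, with compound 1 its only neighbour, but a 1.3-fold higher number from compound 1 to compound 2 (0.10 log units; within the scatter) lies within the scatter, so the two compounds are not separated by these data. Compound 3 `NC(=O)c1ccccc1-c1ccc(COC2CC[C@H](N3CCCCCC3)[C@H]2OC/C=C\CCC(=O)O)cc1` continues from compound 2 by one change: carbamoyl in place of 2-hydroxyethyl on an aromatic carbon. For the measured compounds named here, the only measured step that bears on this position is a 1.3-fold higher number from compound 1 to compound 2 (0.10 log units; within the scatter), which remained within the scatter. On that basis no movement beyond the scatter is expected in this assay, an estimated 1.1-fold lower number from compound 2 to compound 3 (0.02 log units; within the scatter). Compound 3 is therefore expected to give about 30 nM, estimated between 12 nM and 80 nM.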

Compound 3, dissociation constant: 15.9 nM
For compound 3 the middle estimate is 1.9-fold (0.28 log units) above the measured one; the range from low to high includes it.
By their numbers in this assay, from the lowest: compounds 3, 1 and 2 (each within the scatter of the next).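

In this assay, the place on the aromatic carbon, ortho to a large group, now takes a second substituent without any step leaving the scatter: carbamoyl in place of 2-hydroxyethyl gives a 2.0-fold lower number from compound 2 to compound 3 (0.30 log units; within the scatter), and carbamoyl in place of hydrogen gives a 1.6-fold lower number from compound 1 to compound 3 (0.20 log units; within the scatter). Hydrogen, 2-hydroxyethyl and carbamoyl are therefore not separated at this position by these data, although carbamoyl brings nitrogen and a double bond outside aromatic rings. Nothing available gives a reason for these numbers.

The compounds shown leave open whether any group at this place can move the number beyond the scatter. A carboxylic acid, an amine or a longer chain ending in hydroxyl would test how far this tolerance extends.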